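Swapping butyl for isopropyl on a carbonyl carbon

The compounds below may be only part of what the source reports. "The series", "measured", "known", "first", "only" and "open" are said of these compounds alone.

Measured so far in a functional assay on HepG2 cells (Homo sapiens) for cytotoxicity, read by MTT assay (on this read-out higher numbers stand for weaker inhibition and lower numbers for stronger inhibition), for two compounds
Compound 1 `COc1ccc(/C=C/C(=O)c2ccc(OC)c3c2OC(C)(C)C=C3)cc1O` gives 450 nM here
Compound 2 `CCCCC(=O)Oc1cc(/C=C/C(=O)c2ccc(OC)c3c2OC(C)(C)C=C3)ccc1OC` gives 100 nM here

Compound 2 at 100 nM has the lower number of the two. Compound 3 `COc1ccc(/C=C/C(=O)c2ccc(OC)c3c2OC(C)(C)C=C3)cc1OC(=O)C(C)C` carries isopropyl in place of butyl on a carbonyl carbon. Within the data shown here, the one measured step that bears on this is butylcarbonyl in place of hydrogen on an oxygen on an aromatic ring (a 4.5-fold lower number from compound 1 to compound 2 (0.65 log units; beyond the scatter)). That step says nothing about swapping one chain for another, so in this assay only a small step towards a higher number is expected, possibly none beyond the scatter. The expected change is small (a 1.3-fold higher number from compound 2 to compound 3 (0.11 log units; within the scatter)). For compound 3 the estimated value is 130 nM with an expected range from 50 nM to 350 nM in this assay.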

Compound 3, half-maximal inhibitory concentration: 250 nM
For compound 3 the middle estimate is 1.9-fold (0.28 log units) below the measured one, and the stated range covers the measured number.
By their numbers in this assay, from the lowest: compound 2; then compounds 3 and 1 (each within the scatter of the next).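

In this assay, the group on this carbonyl carbon matters: isopropyl in place of butyl gives a 2.5-fold higher number from compound 2 to compound 3 (0.40 log units; beyond the scatter). Adding isopropylcarbonyl to the oxygen of compound 1 gives a 1.8-fold lower number from compound 1 to compound 3 (0.26 log units; within the scatter), so among these compounds only butylcarbonyl moves the number beyond the scatter. Nothing available explains the difference between these two chains.

The compounds shown leave open whether a longer chain, such as hexyl, would lower the number further. They also leave open how an amine on this carbonyl carbon would compare.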